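EP1 binding series: notes on the step to compound 4

The compounds below may be only part of what the source reports. "The series", "measured", "known", "first", "only" and "open" are said of these compounds alone.

Measured compounds in an assay on CHO cells for displacement of a labelled ligand from prostaglandin E2 receptor EP1 subtype (Homo sapiens); a lower number here means a stronger inhibitor, a higher number a weaker inhibitor:
compound 1 `CCc1ccccc1N(Cc1nnc(Cc2ccc(OC)cc2)o1)S(=O)(=O)c1ccc(C)cc1` gives 126 nM; 126 nM (2 entries), two entries with the same value
compound 2 `Cc1ccc(S(=O)(=O)N(Cc2nnc(Cc3ccc(N(C)C)cc3)o2)c2cccc(Cl)c2C)cc1` gives 12.6 nM
compound 3 `COc1ccc(Nc2nnc(CN(c3cccc(Cl)c3Cl)S(=O)(=O)c3ccc(C(F)(F)F)cc3)o2)cc1` gives 7.94 nM

Compound 2 is one of the two compounds with a single number in this assay. Its gap to compound 3 lies within the usual scatter, so the two cannot be told apart on these data. Compound 1, which carries an unsubstituted ethylphenyl on the sulfonamide nitrogen and a methoxybenzyl on the shared core, sits clearly weaker than both.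

Compound 4 `COc1ccc(NCc2nnc(CN(c3cccc(Cl)c3C)S(=O)(=O)c3ccc(C)cc3)o2)cc1` has not yet been measured in this assay. It keeps the sulfonamide portion of compound 2 and differs only in the group on the chain carbon attached to the core: (4-methoxyphenyl)amino in place of 4-(dimethylamino)phenyl on a saturated chain carbon bound to an aromatic carbon. The group that enters in compound 4 is the same (4-methoxyphenyl)amino that compound 3 carries, there bound directly to the core rather than through a chain carbon.

Within the data shown here, nothing in the measured set isolates this change, so no step for it is known. Since the sulfonamide portion of compound 2 is retained, and the entering group is present in the comparably active compound 3, the step is expected to be small, in either direction, and likely not beyond the scatter: a 1.2-fold higher number from compound 2 to compound 4 (0.08 log units; within the scatter). Compound 4 is accordingly estimated at 15 nM in this assay, with a plausible range from 5 nM to 50 nM.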

Compound 4, half-maximal inhibitory concentration: 20 nM
Estimate against measurement, compound 4: 1.3-fold (0.12 log units) below; the range from low to high includes it.
By their numbers in this assay, from the lowest: compounds 3, 2 and 4 (each within the scatter of the next, the first and the last beyond it).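

Among these compounds, the first step that can be read at this position in this assay is a 1.6-fold higher number from compound 2 to compound 4 (0.20 log units; within the scatter), with (4-methoxyphenyl)amino in place of 4-(dimethylamino)phenyl on a saturated chain carbon bound to an aromatic carbon. The exchange keeps the count of 9 heavy atoms and the one six-membered aromatic ring of carbon only, while the group goes from 0 hydrogen-bond donors and 1 hydrogen-bond acceptor to 1 hydrogen-bond donor and 2 hydrogen-bond acceptors, yet compound 2 and compound 4 cannot be told apart on these numbers. No measurement shown here offers an explanation for this result.

From the compounds shown here alone, compound 3 carries the same (4-methoxyphenyl)amino bound directly to the core but differs from compound 4 in other places as well, so no step can be read for the chain carbon itself, and its role stays open. Also open, going by these compounds, is how a carboxylic acid or a longer alkyl chain would read on this chain carbon, and whether the exchange from compound 2 to compound 4 would read the same with a different sulfonamide portion.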